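Swapping a propyl for a cyclopropyl on the amide nitrogen

The source may report more compounds than this note shows. Statements on the series, on what has been measured and on what is new or still open speak of the compounds shown alone.

Measured so far:
Compound 1 `CNC(=O)Cn1nc(N)c2c(C(F)(F)F)cc(-c3ccccc3)nc21` gives 11800 nM in a functional assay on MCF7 cells (Homo sapiens) for cytotoxicity, read by MTT assay, with a stated time of 24 h; a lower number here means a stronger inhibitor, a higher number a weaker inhibitor.
Compound 2 `CCCNC(=O)Cn1nc(N)c2c(C(F)(F)F)cc(-c3ccccc3)nc21` gives 14900 nM in this assay.
Compound 3 `NCCNC(=O)Cn1nc(N)c2c(C(F)(F)F)cc(-c3ccccc3)nc21` gives 42900 nM in this assay.

All three share one core and differ only in the group on the amide-type nitrogen of the side chain. Compound 2 stands second highest of the three numbers, close to compound 1 and further from compound 3. The step of a 1.3-fold higher number from compound 1 to compound 2 (0.10 log units; within the scatter) is within the scatter, so the numbers of compound 1 and compound 2 cannot be told apart. The steps of a 3.6-fold higher number from compound 1 to compound 3 (0.56 log units; beyond the scatter) and a 2.9-fold higher number from compound 2 to compound 3 (0.46 log units; beyond the scatter) are modest rises.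

Compound 4 `Nc1nn(CC(=O)NC2CC2)c2nc(-c3ccccc3)cc(C(F)(F)F)c12` is the next compound, and it differs from compound 2 by cyclopropyl in place of propyl on an amide-type nitrogen. Within the data shown here, no measured step bears directly on this change, which swaps one group of three carbons for another that holds no donor or acceptor. Among the measured compounds shown here, the only step of a similar kind, from hydrogen to ethyl on the chain carbon, stayed within the scatter, while the modest rises both came with an amino group, which compound 4 lacks. The expectation is therefore a step of a 1.1-fold lower number from compound 2 to compound 4 (0.03 log units; within the scatter) that stays within the scatter, with no clear direction. Compound 4 is estimated at 14000 nM in this assay, with a range from 7000 nM to 30000 nM.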

Compound 4, half-maximal inhibitory concentration: "not active" (no number reported)
Nothing numeric was reported for compound 4; no gap can be computed for the estimate.
By their numbers in this assay, from the lowest: compounds 1 and 2 (each within the scatter of the next); then compound 3.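

In this assay, among these compounds, compound 4 is reported only as "not active", without a number, so no step from compound 2 to compound 4 can be read. No evidence is available that would account for this result. The compounds shown leave open how far cyclopropyl on the amide-type nitrogen separates compound 4 from compound 2 numerically.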